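One Bromine Counts; Will a Chlorine Do the Same?

The compounds below may be only part of what the source reports. "The series", "measured", "known", "first", "only" and "open" are said of these compounds alone.

In a functional assay on HCT-116 cells (Homo sapiens) for antiproliferative activity, read by MTT assay, with a stated time of 72 h (on this read-out lower numbers stand for stronger inhibition and higher numbers for weaker inhibition), compound 1 `NC1=NC2(CCOCC2)N(OCCCOc2ccccc2)C(N)=N1` gives 6010 nM. Compound 2 `NC1=NC2(CCOCC2)N(OCCCOc2ccccc2Br)C(N)=N1` gives 30 nM, the lower of the two numbers and so the stronger inhibition. Within the data shown here, only one measured step connects them: a 200-fold lower number from compound 1 to compound 2 (2.30 log units; beyond the scatter), a large change that comes from bromo in place of hydrogen on an aromatic carbon.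

Compound 3 `NC1=NC2(CCOCC2)N(OCCCOc2cccc(Cl)c2)C(N)=N1` keeps the shared core and chain but alters the aromatic ring: 3-chlorophenyl in place of 2-bromophenyl on an oxygen on a saturated carbon. Put simply, it has 3-chlorophenyl in place of 2-bromophenyl on an oxygen on a saturated carbon. Among the measured compounds shown here, the single measured step shows that adding one atom to this ring can matter greatly, but no measured pair separates a change of atom from a change of place. Compound 3 still carries a ring substituent, which compound 1 lacks, so most of the difference between the two measured compounds is expected to remain, with some loss. In this assay the expected change is moderate: a 3.3-fold higher number from compound 2 to compound 3 (0.52 log units; beyond the scatter). For compound 3 the estimated value is 100 nM, with an expected range from 20 nM to 600 nM.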

Compound 3, half-maximal inhibitory concentration: 120 nM
The estimate for compound 3 lay 1.2-fold (0.08 log units) below the measured number; measured number inside the range.
By their numbers in this assay, from the lowest: compound 2; then compound 3; then compound 1.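

In this assay, the large gain is not confined to bromine: a 50-fold lower number from compound 1 to compound 3 (1.70 log units; beyond the scatter) comes with a chlorine added to the bare phenyl ring, so a second halogen on this ring also gives a much lower number than the bare phenyl ring. The change from 2-bromophenyl to 3-chlorophenyl gives a 4.0-fold higher number from compound 2 to compound 3 (0.60 log units; beyond the scatter) and so gives back only a modest part of the gain, leaving compound 3 well ahead of compound 1 but behind compound 2. No measurement at hand explains why either halogen-bearing ring gives so much lower a number than the bare phenyl ring, or why compound 2 stands below compound 3.

The step between compound 2 and compound 3 changes both the halogen and its place on the ring at once, so the compounds shown cannot say how much of the modest loss belongs to each; 2-chlorophenyl or 3-bromophenyl would separate the two. They also leave open whether the gain needs a halogen at all, or whether a ring carrying a methyl or a methoxy group would give a similar number.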